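From 4-fluoropiperidin-1-yl to 3-methoxypiperidin-1-yl on the carbonyl

The source may report more compounds than this note shows. Statements on the series, on what has been measured and on what is new or still open speak of the compounds shown alone.

Of the compounds shown here, two sharing one core have been measured. Compound 1 `O=S(=O)(c1ccc(Cl)cc1)N1CC(c2nc(-c3cccc(Cl)c3)no2)C1` reaches only the limit of an assay on HEK293 cells for positive allosteric modulation of metabotropic glutamate receptor 5 (Homo sapiens), read by FLIPR (a lower number here means that less compound is needed, a higher number that more compound is needed for the effect), reported as > 10000 nM. In this assay compound 2 `O=C(N1CCC(F)CC1)N1CC(c2nc(-c3cccc(Cl)c3)no2)C1` gives 990 nM, the only full number shown. The other value, that of compound 1, is a limit (the limit of > 10000 nM in this assay, at which 1 of the 2 values shown sits). Compound 3 `COC1CCCN(C(=O)N2CC(c3nc(-c4cccc(Cl)c4)no3)C2)C1` differs from compound 2 by 3-methoxypiperidin-1-yl in place of 4-fluoropiperidin-1-yl on a carbonyl carbon. Among the measured compounds shown here, no measured pair shows this change, so the expectation rests on compound 2 alone, and no shift beyond the usual scatter is expected in either direction. Compound 3 is estimated at 1100 nM, between 350 nM and 3500 nM, an expected step of a 1.1-fold higher number from compound 2 to compound 3 (0.05 log units; within the scatter).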

Compound 3, half-maximal effective concentration: > 10000 nM
Compound 3 ended at the assay's limit (the forecaster's own chance of this, stated with the estimate: 15%); middle value at least 9.0-fold (0.95 log units) from the limit.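

Replacing 4-fluoropiperidin-1-yl with 3-methoxypiperidin-1-yl on the carbonyl carbon gives an at least 10-fold higher number from compound 2 to compound 3 (1.00 log units; beyond the scatter) in this assay, so this position is sensitive to the choice of substituted piperidine. Compound 3 gives > 10000 nM, which is a limit. Only compound 2 now has a full number, and the others sit at the limit: the limit of > 10000 nM in this assay, at which 2 of the 3 values shown sit.

The compounds shown leave open whether the step follows the methoxy group itself or its place on the ring. Comparing 4-methoxypiperidin-1-yl and 3-fluoropiperidin-1-yl on the same carbonyl would separate these two possibilities.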